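The source may report more compounds than this note shows. Statements on the series, on what has been measured and on what is new or still open speak of the compounds shown alone.

Values so far in an ADME assay on LL24 cells (Homo sapiens) for inhibition, read by MTT assay, with a stated time of 24 h; on this read-out higher numbers stand for weaker inhibition and lower numbers for stronger inhibition:
- compound 1 `CCCOc1ccc(C(=O)N/N=C/c2ccc([N+](=O)[O-])o2)cc1` gives > 200000 nM as a limit
- compound 2 `O=C(N/N=C/c1ccc([N+](=O)[O-])o1)c1ccc(-c2ccccc2)cc1` gives > 200000 nM as a limit

Compound 2 has no number of its own, only a limit, and the same holds for compound 1. The whole record so far is the limit of > 200000 nM in this assay, at which 2 of the 2 values shown sit, and nothing more. Compound 3 `N#Cc1ccc(C(=O)N/N=C/c2ccc([N+](=O)[O-])o2)cc1` keeps the core of compound 2 and changes one group. The change is cyano in place of phenyl on an aromatic carbon and in words it puts cyano in place of phenyl on an aromatic carbon, para to a large group. Going by the values given here, the only measured step that bears on this is a step that the two limits leave unreadable from compound 1 to compound 2 and it alters the same aromatic carbon without leaving the limit. No step beyond the usual scatter is therefore expected in this assay and no direction can be given. The estimated move is a number no higher from compound 2 to compound 3 (the limit leaves the size open) and it rests on that one unreadable step. For compound 3 the expected value is 200000 nM with an estimated range from 80000 nM to 400000 nM for the coming measurement.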

Compound 3, half-maximal inhibitory concentration: > 200000 nM
Compound 3: only a limit was reported; the forecaster's own chance of this, stated with the estimate: 70%; the middle value lies on the limit itself.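

In this assay compound 3 gives > 200000 nM, which is a limit and not a number. No step among compound 1, compound 2 and compound 3 can therefore be read: the limit of > 200000 nM in this assay, at which 3 of the 3 values shown sit.

These compounds leave open whether propoxy, phenyl and cyano differ at all in this assay.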